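Working notes: from compound 3 to compound 4

The compounds below may be only part of what the source reports. "The series", "measured", "known", "first", "only" and "open" are said of these compounds alone.

Measured in a physicochemical assay, read by spectrophotometry, with a stated time of 30 min; a higher number here means a weaker inhibitor, a lower number a stronger inhibitor:
- Compound 1 `COc1cc(/C=C/C(=O)NCCC2CCN(Cc3ccccc3)CC2)cc(OC)c1O`: 24900 nM
- Compound 2 `COc1cc(CCC(=O)NC2CCN(Cc3ccccc3)CC2)ccc1O`: 55100 nM
- Compound 3 `COc1cc(/C=C/C(=O)CC(=O)NC2CCN(Cc3ccccc3)CC2)ccc1O`: 88700 nM

Compound 3 lies within the scatter of compound 2, and on the weaker side of compound 1 by more than the scatter. Compound 4 `O=C(/C=C/c1ccc(O)cc1)CC(=O)NC1CCN(Cc2ccccc2)CC1` has hydrogen in place of methoxy on an aromatic carbon, the change from 4-hydroxy-3-methoxyphenyl to 4-hydroxyphenyl (hydrogen in place of methoxy on an aromatic carbon). Going by the values given here, no measured pair shows this change alone, so no step beyond the scatter is expected in this assay, and neither direction is favoured. The expected change is a 1.1-fold lower number from compound 3 to compound 4 (0.04 log units; within the scatter), a step within the scatter. The estimate for compound 4 is 80000 nM, with an expected range from 35000 nM to 180000 nM.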

Compound 4, half-maximal inhibitory concentration: 890000 nM
Beside the measured number, compound 4's estimate is 11-fold (1.05 log units) below it; measured number outside the range, above it.
By their numbers in this assay, from the lowest: compound 1; then compounds 2 and 3 (each within the scatter of the next); then compound 4.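

Hydrogen in place of methoxy, on the aromatic carbon ortho to a hydroxy group, gives a 10-fold higher number from compound 3 to compound 4 (1.00 log units; beyond the scatter) in this assay. Going by these compounds alone, this is the first pair that differs in one place, and it shows that this position is not indifferent to the change. No measurement shown here accounts for the step.

Going by these compounds, whether methoxy itself is required remains open, since ethoxy, fluoro or hydroxy on this carbon would test that. On these data alone, whether the same change gives a similar step on the core of compound 1 or compound 2 also remains open.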